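Second fluoro on the N-aryl ring of the pyridazinone amide

A few compounds are considered here, and "the series" means these few. Any claim that something is new, unique, unknown or untested is made for them only; others in the source may bear on it.

Compound 2 `Cc1cc(=O)n(-c2ccc(F)cc2)nc1C(=O)Nc1ccc(Oc2ncnc3ccsc23)c(F)c1` and compound 1 `Cc1cc(=O)n(-c2ccc(Br)cc2F)nc1C(=O)Nc1ccc(Oc2ncnc3ccsc23)c(F)c1` share the same core and differ only in the aryl group on the ring nitrogen. For the measured compounds named here, in a functional assay on HepG2 cells (Homo sapiens) for cytotoxicity, read by MTT assay, with a stated time of 72 h (a higher number here means a weaker inhibitor, a lower number a stronger inhibitor), compound 2 gives 470 nM, the lowest of the two numbers so far; compound 1 gives 3350 nM. Going by the values given here, the one measured step, a 7.1-fold lower number from compound 1 to compound 2 (0.85 log units; beyond the scatter), shows that the halogen pattern on this ring moves the number by a modest amount.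

Compound 3 `Cc1cc(=O)n(-c2ccc(F)c(F)c2)nc1C(=O)Nc1ccc(Oc2ncnc3ccsc23)c(F)c1` takes the next step from compound 2: fluoro in place of hydrogen on an aromatic carbon, the site being ortho to a fluoro group and meta to a large group, so that 4-fluorophenyl becomes 3,4-difluorophenyl. Among the compounds with values here, the only step that bears on it is the one from compound 1 to compound 2, in which a more halogenated ring gave the higher number; compound 3 adds a halogen to the ring of compound 2, but in a different position than in compound 1, so a smaller move is expected, most likely upward and possibly within the scatter. On this basis compound 3 is estimated at 750 nM in this assay, in the range 250 nM to 2200 nM, a step of a 1.6-fold higher number from compound 2 to compound 3 (0.20 log units; within the scatter) from compound 2.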

Compound 3, half-maximal inhibitory concentration: 6930 nM
Compound 3: the middle estimate sits 9.2-fold (0.97 log units) below what was measured, outside the stated range (above it).
By their numbers in this assay, from the lowest: compound 2; then compound 1; then compound 3.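

In this assay a single fluoro added to the aromatic carbon ortho to the existing fluoro group, turning 4-fluorophenyl into 3,4-difluorophenyl, gives a 15-fold higher number from compound 2 to compound 3 (1.17 log units; beyond the scatter) and so moves the number further than the whole change of ring pattern seen earlier. Set against the 4-bromo-2-fluorophenyl ring, the 3,4-difluorophenyl ring gives a 2.1-fold higher number from compound 1 to compound 3 (0.32 log units; beyond the scatter) and makes compound 3 the weakest of the three, so which halogen sits at which ring position matters, not merely the presence of added halogen. Nothing measured here accounts for the size of this rise, which remains unexplained.

Still open, from the compounds shown here alone, is whether the rise belongs to fluoro itself or would follow any substituent on this carbon, a question that a methoxy group or an amine at the same site would help to settle. Also open, going by these compounds, is whether the rise depends on the existing 4-fluoro group, which an unsubstituted phenyl ring and a 3-fluorophenyl ring would show.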